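Ethyl for phenyl on the triazole nitrogen: oxime anilides

The source may report more compounds than this note shows. Statements on the series, on what has been measured and on what is new or still open speak of the compounds shown alone.

Measured in a functional assay on the whole organism (strain albino) for inhibition, with Rattus norvegicus as the target, read by paw edema, with stated times of 30 min and 4 h, at a dose of 0.28 mmol/kg by the oral route; a higher number here means more inhibition at the dose given (going by the name of the read-out), a lower number less inhibition:
compound 1 `CCn1c(SCC(=O)Nc2ccc(/C(C)=N/O)cc2)nnc1-c1ccc(OC)c(OC)c1` gives 75%
compound 2 `COc1ccc(-c2nnc(SCC(=O)Nc3ccc(/C(C)=N/O)cc3)n2-c2ccccc2)cc1` gives 69%

Compound 2 has the smaller of the two figures, but its gap to compound 1 lies within the scatter, so the two are not separated on these data. Compound 3 `CCn1c(SCC(=O)Nc2ccc(/C(C)=N/O)cc2)nnc1-c1ccc(OC)cc1` is not yet measured. It differs from compound 2 by ethyl in place of phenyl on an aromatic nitrogen. Compound 1 also carries an ethyl at that nitrogen and gives 75%, so no step beyond the scatter is expected from compound 2 to compound 3 in this assay; the estimated step is a number 3 percentage points higher from compound 2 to compound 3 (within the scatter). Compound 3 is expected to give 72%, within 60% to 82%.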

Compound 3, a percentage reported as inhibition, in the whole organism at one dose (the size of the read-out at that dose, not a potency): 73%
Compound 3: the middle estimate sits 1 percentage points below what was measured, and the stated range covers the measured number.
By their numbers in this assay, from the lowest: compounds 2, 3 and 1 (each within the scatter of the next).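

Ethyl in place of phenyl on the aromatic nitrogen gives a number 4 percentage points higher from compound 2 to compound 3 (within the scatter) in this assay, so the two groups are not separated at this position while the 4-methoxyphenyl group is kept. Hydrogen in place of methoxy on an aromatic carbon gives a number 2 percentage points lower from compound 1 to compound 3 (within the scatter), so with ethyl on the nitrogen that methoxy is not separated from hydrogen either. No measurement at hand accounts for either step.

Still open, from the compounds shown here alone, is how this nitrogen responds to a longer chain such as butyl or to a chain ending in an amine or a carboxylic acid. Potency also remains open, as only a single dose is shown.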